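Swapping an acid for an amine on a weak series

The source may hold more compounds than are shown below. What is called first, only, known or untested is meant among the compounds shown, and "the series" means these compounds.

In an assay on 32D cells for inhibition of interleukin-15 (Mus musculus), read by resazurin assay, with stated times of 30 min and 2.5 days, in the presence of a further agent that is not named here (on this read-out lower numbers stand for stronger inhibition and higher numbers for weaker inhibition), compound 1 `Cn1c(Cc2nn(C)c(=O)c3ccccc23)nnc1SCC(=O)Nc1ccc(Cl)cc1Cl` gives 22500 nM, and compound 2 `Cn1c(Cc2nn(CCC=O)c(=O)c3ccccc23)nnc1SCC(=O)Nc1ccc(Cl)cc1Cl` gives 30000 nM. Compound 3 `Cn1c(Cc2nn(CCC(=O)O)c(=O)c3ccccc23)nnc1SCC(=O)Nc1ccc(Cl)cc1Cl` reaches only a limit of this assay, > 30000 nM, so it stands at the edge of what the measurement reports rather than at a number, as the limit of > 30000 nM in this assay, at which 1 of the 3 values shown sits, records. The steps seen so far are small: a 1.3-fold higher number from compound 1 to compound 2 (0.12 log units; within the scatter), an at least 1.3-fold higher number from compound 1 to compound 3 (0.12 log units; that floor lies within the scatter), and a number no lower from compound 2 to compound 3 (the limit leaves the size open). Compound 4 `CN(C)CCCn1nc(Cc2nnc(SCC(=O)Nc3ccc(Cl)cc3Cl)n2C)c2ccccc2c1=O` differs from compound 3 by (dimethylamino)methyl in place of carboxy on a saturated chain carbon, two bonds along the chain from an aromatic nitrogen. For the measured compounds named here, no measured step touches an amine of this kind, so the expected step of an at least 1.5-fold lower number from compound 3 to compound 4 (0.17 log units; that floor lies within the scatter) is none beyond the scatter. Compound 4 is therefore estimated at 20000 nM, with a range from 5000 nM to 60000 nM.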

Compound 4, half-maximal inhibitory concentration: 18800 nM
Estimate against measurement, compound 4: 1.1-fold (0.03 log units) above; the measured number falls inside the stated range.
By their numbers in this assay, from the lowest: compounds 4, 1 and 2 (each within the scatter of the next).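

In this assay, 3-(dimethylamino)propyl in place of 2-carboxyethyl gives an at least 1.5-fold lower number from compound 3 to compound 4 (0.20 log units; that floor lies within the scatter). Set against the other two groups at this position, the same amine chain gives a 1.6-fold lower number from compound 2 to compound 4 (0.20 log units; within the scatter) and a 1.2-fold lower number from compound 1 to compound 4 (0.08 log units; within the scatter), so this amine moves the number beyond the scatter from neither of them. Compound 3 itself stands at a limit of the assay: the limit of > 30000 nM in this assay, at which 1 of the 4 values shown sits.

Going by these compounds, whether a primary amine, a morpholine or a shorter amine chain at this position would move the number beyond the scatter stays open. So does the effect of any change elsewhere on the shared core.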